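From a Butoxy Chain to a Cyclohexyloxy Ring

The compounds below may be only part of what the source reports. "The series", "measured", "known", "first", "only" and "open" are said of these compounds alone.

Compound 3 `CCCCOCNc1n[n+]([O-])c2ccccc2[n+]1[O-]` gives 6010 nM in a functional assay on PC-3 cells (Homo sapiens) for cytotoxicity, read by MTT assay, with a stated time of 72 h; a lower number here means a stronger inhibitor, a higher number a weaker inhibitor. Among the three measured compounds it has the lowest number, but compound 1 `CCCOCNc1n[n+]([O-])c2cc(OC)ccc2[n+]1[O-]`, which gives 10600 nM, lies within the scatter of it, so the two cannot be ranked against each other. Compound 2 `COc1ccc(COCNc2n[n+]([O-])c3ccccc3[n+]2[O-])cc1` gives 52800 nM, a clearly higher number. Among the compounds with values here, the only step between two compounds that differ in one place is an 8.8-fold lower number from compound 2 to compound 3 (0.94 log units; beyond the scatter), in which an open propyl chain took the place of a methoxyphenyl group. Compound 4 `[O-][n+]1nc(NCOC2CCCCC2)[n+]([O-])c2ccccc21` differs from compound 3 by cyclohexyl in place of butyl on an oxygen on a saturated carbon. Within the data shown here, no measured pair shows this exact change. The step from compound 2 to compound 3 shows only that a smaller open chain gave a lower number than a larger ring-bearing group on the same oxygen, and compound 4 moves back toward a larger, ring-bearing group, though a saturated one. The change is therefore expected to shift this assay only slightly, with a lean toward a higher number that may well stay within the scatter. Compound 4 is expected to give 8500 nM, within 3000 nM to 25000 nM. The expected step is a 1.4-fold higher number from compound 3 to compound 4 (0.15 log units; within the scatter).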

Compound 4, half-maximal inhibitory concentration: 6670 nM
Beside the measured number, compound 4's estimate is 1.3-fold (0.11 log units) above it; low and high end bracket the measured number.
By their numbers in this assay, from the lowest: compounds 3, 4 and 1 (each within the scatter of the next); then compound 2.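

In this assay, the exchange of butyl for cyclohexyl on an oxygen on a saturated carbon gives a 1.1-fold higher number from compound 3 to compound 4 (0.05 log units; within the scatter), which lies within the scatter, so compound 3 and compound 4 cannot be told apart here. Within the data shown here, the only earlier step at this part of the molecule, an 8.8-fold lower number from compound 2 to compound 3 (0.94 log units; beyond the scatter), set an open chain against a group carrying a methoxyphenyl ring, and on its own it left room to read any ring there as going with a higher number; compound 4, with its six-membered non-aromatic ring of carbon only, goes against that reading. Nothing measured alongside these numbers explains why the open chain and the saturated ring cannot be separated in this assay.

As far as these compounds go, it remains open whether a longer chain such as octyl, or a cyclohexyl ring carrying an amine or a carboxylic acid, would stay within the scatter of compound 3 or move clearly away from it. Also open, from the compounds shown here alone, is whether a plain phenyl ring, without the methoxy group, would give a number close to that of compound 4 or close to that of compound 2.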